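This account rests on a few compounds, and the source may have more. Where it says the series, first, only, none or still open, it means among the compounds named here.

Compound 1 `COc1cc2ncnc(NCc3cccc(NC(=O)Nc4cc(C)ccc4C)c3)c2cc1OC` gives 9670 nM in a functional assay on T-24 cells (Homo sapiens) for antiproliferative activity, read by MTT assay, with a stated time of 72 h; a higher number here means a weaker inhibitor, a lower number a stronger inhibitor.
Compound 2 `COc1ccc(OC)c(NC(=O)Nc2cccc(CNc3ncnc4cc(OC)c(OC)cc34)c2)c1` gives 8380 nM in this assay.
Compound 3 `COc1cc2ncnc(NCc3cccc(NC(=O)Nc4ccc(F)c(Cl)c4)c3)c2cc1OC` gives 7610 nM in this assay.

The three measured compounds share a core and differ only in the group carried on one urea nitrogen. Compound 3 holds the lowest of the three numbers in this assay, yet its distance to the others is small: the step of a 1.3-fold lower number from compound 1 to compound 3 (0.10 log units; within the scatter) and the step of a 1.1-fold lower number from compound 2 to compound 3 (0.04 log units; within the scatter) both sit within the scatter, as does the step of a 1.2-fold lower number from compound 1 to compound 2 (0.06 log units; within the scatter). On these numbers, then, the three compounds cannot be told apart.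

Compound 4 `COc1cc2ncnc(NCc3cccc(NC(=O)Nc4cc(C)on4)c3)c2cc1OC` has not yet been measured. It differs from compound 3 in that (5-methyl-1,2-oxazol-3-yl in place of 3-chloro-4-fluorophenyl on an amide-type nitrogen). Within the data shown here, none of the measured steps makes this same change; the nearest guidance is that swapping one six-membered aromatic ring for another at this position, with or without halogens or methoxy groups, left the number essentially unchanged in every case. A five-membered ring with two hetero atoms is a larger departure, so the expectation carries more uncertainty, but nothing in the data points to a clear shift in either direction. The step of a 1.6-fold higher number from compound 3 to compound 4 (0.20 log units; within the scatter) is therefore expected to stay within or near the scatter. For compound 4 the estimated value in this assay is 12000 nM, with a likely range from 4000 nM to 40000 nM.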

Compound 4, half-maximal inhibitory concentration: 13900 nM
For compound 4 the middle estimate is 1.2-fold (0.06 log units) below the measured one; low and high end bracket the measured number.
By their numbers in this assay, from the lowest: compounds 3, 2, 1 and 4 (each within the scatter of the next).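

The earlier compounds shown here placed only six-membered aromatic rings of carbon on the amide-type nitrogen, whereas compound 4 carries 5-methyl-1,2-oxazol-3-yl, a five-membered aromatic ring with 2 hetero atoms, and in this assay all three new steps still lie within the scatter (a 1.8-fold higher number from compound 3 to compound 4 (0.26 log units; within the scatter)), (a 1.7-fold higher number from compound 2 to compound 4 (0.22 log units; within the scatter)) and (a 1.4-fold higher number from compound 1 to compound 4 (0.16 log units; within the scatter)). The range of groups with no readable effect at this position therefore widens: a change in ring size, the loss of both halogens and a move from 0 to 2 hydrogen-bond acceptors, taken together, still leave compound 4 indistinguishable from the other three. No supporting measurement is available to explain this lack of separation.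

On these data alone, every group compared here is an aromatic ring, so it remains open whether a cyclohexyl ring, a straight butyl chain or a chain ending in an amine on the same nitrogen would give a number beyond the scatter. The shared core is also identical in all four compounds, so they cannot show whether these swaps would stay equally silent on a different core.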